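Isopropyl in place of cyclopropyl on an aromatic nitrogen

The source may report more compounds than this note shows. Statements on the series, on what has been measured and on what is new or still open speak of the compounds shown alone.

In an ADME assay on Caco-2 cells (Homo sapiens) for permeability (on this read-out higher numbers stand for higher permeability and lower numbers for lower permeability), compound 1 `Nc1cc(-c2cccc(-n3ccc4cc(C5CC5)cc(F)c4c3=O)c2CO)nc(Nc2cnn(C3CC3)c2)n1` gives 6.9 10^-6 cm/s. Within the data shown here, its only measured neighbour, compound 2 `Nc1cc(-c2cccc(-n3ccc4cc(C5CC5)cc(F)c4c3=O)c2CO)nc(Nc2cnn(CC3CC3)c2)n1`, gives 6.1 10^-6 cm/s, and the two numbers lie within the scatter of each other, so compound 1 stands level with compound 2 on this evidence.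

Compound 3 `CC(C)n1cc(Nc2nc(N)cc(-c3cccc(-n4ccc5cc(C6CC6)cc(F)c5c4=O)c3CO)n2)cn1` is not yet measured. It differs from compound 1 as follows: isopropyl in place of cyclopropyl on an aromatic nitrogen. In short, isopropyl stands in place of cyclopropyl on an aromatic nitrogen. Among the measured compounds shown here, one measured step bears on this change: a 1.1-fold lower number from compound 1 to compound 2 (0.05 log units; within the scatter), with cyclopropylmethyl in place of cyclopropyl on an aromatic nitrogen. For the measured compounds named here, no measured compound yet carries isopropyl, so the support is thin. No change beyond the scatter is expected in this assay. The expected step is a 1.1-fold lower number from compound 1 to compound 3 (0.03 log units; within the scatter), an estimate within the scatter. Compound 3 is estimated at 6.5 10^-6 cm/s, with an expected range of 3.5 10^-6 cm/s to 12 10^-6 cm/s.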

Compound 3, apparent permeability in the Caco-2 assay: 3.7 10^-6 cm/s
Compound 3: the middle estimate sits 1.8-fold (0.24 log units) above what was measured; low and high end bracket the measured number.
By their numbers in the Caco-2 assay, from the lowest: compounds 3, 2 and 1 (each within the scatter of the next).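

In the Caco-2 assay isopropyl on the aromatic nitrogen gives a 1.9-fold lower number from compound 1 to compound 3 (0.27 log units; within the scatter) and a 1.6-fold lower number from compound 2 to compound 3 (0.22 log units; within the scatter), so cyclopropyl, cyclopropylmethyl and isopropyl cannot be told apart at this position on this read-out. In a physicochemical assay for solubility, read by LC-MS, in phosphate buffer, measured as kinetic solubility, with a stated time of 1 h, at pH 7.4 (a lower number here means a less soluble compound, a higher number a more soluble compound), compound 1 gives 9800 nM and compound 3 gives 4000 nM on this read-out. In the physicochemical assay the exchange of a carbon ring for an open chain with the same heavy-atom count does separate the compounds, so at this position the change shows in solubility and not in permeability: the measured solubility of compound 1, 9800 nM, and of compound 3, 4000 nM, a 2.5-fold lower number (0.39 log units; beyond the scatter)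

Going by these compounds, that solubility comparison rests on a single pair, so it remains open whether other open-chain groups on this nitrogen would behave as isopropyl does. The groups shown are all carbon only, which leaves open how an amine or a carboxylic acid at this position would read in either assay.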